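Notes on compound 2 and its acetamido chain variant

The source may report more compounds than this note shows. Statements on the series, on what has been measured and on what is new or still open speak of the compounds shown alone.

compound 1 `O=c1cc(-c2ccccc2)[nH]c(=O)n1O` — > 100000 nM
compound 2 `CCCNC(=O)c1nc(-c2cccs2)[nH]c(=O)c1O` — > 100000 nM

In an assay on isolated protein for inhibition of deoxyribonuclease-1 (Homo sapiens) (on this read-out higher numbers stand for weaker inhibition and lower numbers for stronger inhibition), compound 1 gives only a limit, > 100000 nM. Compound 2 likewise gives only a limit in this assay, > 100000 nM. For the measured compounds named here, both measurements share the same limit, (the limit of > 100000 nM in this assay, at which 2 of the 2 values shown sit), so no measured step exists and compound 2 stands only at that limit. Compound 3 `CC(=O)NCCNC(=O)c1nc(-c2cccs2)[nH]c(=O)c1O` differs from compound 2 by acetamido in place of methyl on a saturated chain carbon, two bonds along the chain from an amide-type nitrogen, in words acetamido in place of methyl on a saturated chain carbon, two bonds along the chain from an amide-type nitrogen. Going by the values given here, with no measured step to rest on, no change beyond the scatter is expected. The implied step, a step that the limit leaves unreadable from compound 2 to compound 3, is expected to stay within the scatter. Compound 3 is expected at 150000 nM, range 30000 nM to 600000 nM.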

Compound 3, half-maximal inhibitory concentration: 62600 nM
Beside the measured number, compound 3's estimate is 2.4-fold (0.38 log units) above it; low and high end bracket the measured number.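

In this assay, for the compounds shown here, compound 3 gives 62600 nM, the first reading that is a number and not a limit. Acetamido in place of methyl on a saturated chain carbon, two bonds along the chain from an amide-type nitrogen, gives an at least 1.5-fold lower number from compound 2 to compound 3 (0.20 log units; that floor lies within the scatter). The true size of this step cannot be read, because compound 2 stands only at a limit: the limit of > 100000 nM in this assay, at which 2 of the 3 values shown sit.

From the compounds shown here alone, it remains open whether the acetamido group itself matters or whether a longer chain, an amine or a carboxylic acid at this place would read the same.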